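Aryl exchange on the amide nitrogen: working notes

The compounds below may be only part of what the source reports. "The series", "measured", "known", "first", "only" and "open" are said of these compounds alone.

Compound 1 `CCOC1=C(/C(C)=N/OCC(=O)Nc2c(F)cccc2F)N(C)S(=O)(=O)c2ccccc21` carries a 2,6-difluorophenyl on the amide-type nitrogen and an ethyl on the oxygen on the unsaturated carbon. In a functional assay on THP-1 cells (Homo sapiens) for inhibition, read by ELISA, with stated times of 2 h and 48 h (on this read-out higher numbers stand for weaker inhibition and lower numbers for stronger inhibition), compound 1 returns only a limit, > 20000 nM. Compound 2 `CCOC1=C(/C(C)=N/OCC(=O)Nc2ccc(Cl)c(C(F)(F)F)c2)N(C)S(=O)(=O)c2ccccc21` differs from compound 1 in one place: 4-chloro-3-(trifluoromethyl)phenyl in place of 2,6-difluorophenyl on an amide-type nitrogen. In this assay compound 2 also sits at a limit, > 20000 nM. The step that the two limits leave unreadable from compound 1 to compound 2 cannot be read, because the limit of > 20000 nM in this assay, at which 3 of the 3 values shown sit, covers both ends of it.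

Compound 3 `C/C(=N\OCC(=O)Nc1c(F)cccc1F)C1=C(O)c2ccccc2S(=O)(=O)N1C` keeps the 2,6-difluorophenyl of compound 1 but has a different core: hydrogen in place of ethyl on an oxygen on an unsaturated carbon. In this assay compound 3 is again a limit, > 20000 nM. The step that the two limits leave unreadable from compound 1 to compound 3 is equally hidden by the limit of > 20000 nM in this assay, at which 3 of the 3 values shown sit.

Compound 4 `C/C(=N\OCC(=O)Nc1ccc(Cl)c(C(F)(F)F)c1)C1=C(O)c2ccccc2S(=O)(=O)N1C` is not yet measured in this assay. It is reached from compound 3 by 4-chloro-3-(trifluoromethyl)phenyl in place of 2,6-difluorophenyl on an amide-type nitrogen; the place reads the same word for word as for the pair of compound 1 and compound 2, so this is the same change, carried on the core of compound 3 rather than the core of compound 1. Since the size of a step that the two limits leave unreadable from compound 1 to compound 2 is not readable, nothing measured shows whether the change moves inhibition in either direction. For the measured compounds named here, the only anchor is that every value so far is a limit, (the limit of > 20000 nM in this assay, at which 3 of the 3 values shown sit). The expected step is a step that the limit leaves unreadable from compound 3 to compound 4, essentially flat, because a step that the two limits leave unreadable from compound 1 to compound 2 gives no sign of a shift. Compound 4 is therefore expected to return another limit or a high number, estimated at 30000 nM with a range from 12000 nM to 100000 nM.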

Compound 4, half-maximal inhibitory concentration: > 20000 nM
Compound 4 gave a limit, no number; the forecaster's own chance of this, stated with the estimate: 85%; the middle value lies beyond the limit too.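

In this assay compound 4 gives > 20000 nM, a limit and not a number. Neither step into compound 4, from compound 3 or from compound 2, can be read, because both ends of each step sit at the same limit: the limit of > 20000 nM in this assay, at which 4 of the 4 values shown sit.

The compounds shown leave open whether either change, the aryl exchange on the amide-type nitrogen or hydrogen in place of ethyl, moves inhibition at all.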